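Shifting Fluorine Within the Fluorophenyl Group of Compound 1

A few compounds are considered here, and "the series" means these few. Any claim that something is new, unique, unknown or untested is made for them only; others in the source may bear on it.

Going by the values given here, compound 1 `COc1ccccc1-c1nnc(-c2ccc(C(=O)N/N=C/c3ccc(F)cc3)cc2)o1` is one of two compounds measured in an ADME assay on THP-1 cells (Homo sapiens) for cytotoxicity (on this read-out higher numbers stand for weaker inhibition and lower numbers for stronger inhibition), where compound 1 gives 427000 nM, the highest of the two numbers. Compound 2 `COc1ccc(O)c(/C=N/NC(=O)c2ccc(-c3nnc(-c4ccccc4OC)o3)cc2)c1` gives 303000 nM in this assay. Among the compounds with values here, the only measured step, a 1.4-fold lower number from compound 1 to compound 2 (0.15 log units; within the scatter), exchanged the whole 4-fluorophenyl for 2-hydroxy-5-methoxyphenyl on a carbon with a double bond to nitrogen and stayed within the scatter. Compound 3 `COc1ccccc1-c1nnc(-c2ccc(C(=O)N/N=C/c3ccccc3F)cc2)o1` differs from compound 1 by 2-fluorophenyl in place of 4-fluorophenyl on a carbon with a double bond to nitrogen. Within the data shown here, this change sits on the same carbon with a double bond to nitrogen as the one measured step, which remained within the scatter even though it swapped a larger set of groups, so for compound 3 a step of a 1.0-fold lower number from compound 1 to compound 3 (0.01 log units; within the scatter) in this assay is expected, with no direction beyond the scatter. Compound 3 is therefore estimated at 420000 nM, with an expected range from 200000 nM to 900000 nM.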

Compound 3, half-maximal inhibitory concentration: 313000 nM
Compound 3: the middle estimate sits 1.3-fold (0.13 log units) above what was measured, within the range that was stated.
By their numbers in this assay, from the lowest: compounds 2, 3 and 1 (each within the scatter of the next).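

With the same atoms joined differently, 2-fluorophenyl in place of 4-fluorophenyl gives a 1.4-fold lower number from compound 1 to compound 3 (0.13 log units; within the scatter) in this assay, so moving the fluorine on this ring does not take the read-out beyond the scatter. The step of a 1.0-fold higher number from compound 2 to compound 3 (0.01 log units; within the scatter) adds that 2-fluorophenyl and 2-hydroxy-5-methoxyphenyl cannot be told apart here either, and all three groups on this carbon with a double bond to nitrogen now lie within the scatter of one another. Nothing available explains these numbers.

The compounds shown leave open whether 3-fluorophenyl, or a ring carrying an amine or a carboxylic acid, would give a step beyond the scatter at this place. They also leave open whether any change to the shared core would do so, since all three compounds keep it unchanged.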